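Methyl to Fluoro Swap on Two Related Cores

This account rests on a few compounds, and the source may have more. Where it says the series, first, only, none or still open, it means among the compounds named here.

Measured so far:
Compound 1 `Cc1ccc(S(=O)(=O)N[C@H]2CC/C(=N\OCC3CCCCC3)[C@@H]2C/C=C\CCCC(=O)O)cc1`: 600 nM in a functional assay (plasma) for inhibition, with Homo sapiens as the target; on this read-out higher numbers stand for weaker inhibition and lower numbers for stronger inhibition
Compound 2 `O=C(O)CCC/C=C\C[C@H]1/C(=N/OCC2CCCCC2)CC[C@@H]1NS(=O)(=O)c1ccc(F)cc1`: 1800 nM in this assay
Compound 3 `Cc1ccc(S(=O)(=O)N[C@H]2CCC(=O)[C@@H]2C/C=C\CCCC(=O)O)cc1`: 670 nM in this assay

Compound 2 differs from compound 1 by fluoro in place of methyl on an aromatic carbon, and this change gave a 3.0-fold higher number from compound 1 to compound 2 (0.48 log units; beyond the scatter). Compound 4 `O=C(O)CCC/C=C\C[C@H]1C(=O)CC[C@@H]1NS(=O)(=O)c1ccc(F)cc1` is not yet measured; it differs from compound 3 by fluoro in place of methyl on an aromatic carbon, the same change at the same kind of place. The difference between the two cores, that of compound 1 and that of compound 3, is not broken down here; compound 1 and compound 3 give numbers that lie within the scatter of each other. Within the data shown here, compound 4 is expected to show a step of roughly the same size as the measured one, a 3.0-fold higher number from compound 3 to compound 4 (0.47 log units; beyond the scatter), because the single earlier example of this change gave a 3.0-fold higher number from compound 1 to compound 2 (0.48 log units; beyond the scatter). Among the measured compounds shown here, with only one example the spread is wide. The estimate for compound 4 in this assay is 2000 nM, between 900 nM and 4500 nM.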

Compound 4, half-maximal inhibitory concentration: 500 nM
The estimate for compound 4 lay 4.0-fold (0.60 log units) above the measured number, outside the stated range (below it).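

In this assay, swapping methyl for fluoro on the core of compound 3 gave a step that cannot be told from the usual scatter, a 1.3-fold lower number from compound 3 to compound 4 (0.13 log units; within the scatter), unlike the clear step seen on the core of compound 1. The effect of this change therefore did not carry over with the same size from one core to the other: the same change on two cores in this assay, a 3.0-fold higher number (0.48 log units; beyond the scatter) from compound 1 to compound 2 and a 1.3-fold lower number (0.13 log units; within the scatter) from compound 3 to compound 4, 4.0-fold (0.60 log units) apart, beyond the scatter of two such steps

This comparison rests on a single pair for each core, and it does not show what in the cores produces the gap or how the change would behave on a third core. The compounds shown carry only methyl or fluoro at this place on the aromatic ring, so it stays open whether chloro or methoxy would also give steps that depend on the core. As far as these compounds go, it also stays open which part of the difference between the two cores matters, as that difference is not broken down into single changes.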